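Ethyl ester and aromatic carbamoyl: expectation for compound 4

The compounds below may be only part of what the source reports. "The series", "measured", "known", "first", "only" and "open" are said of these compounds alone.

Compound 2 `CCOC(=O)c1oc2cc(OCc3ccccc3)cc(OCc3ccccc3)c2c1C` is tested in a functional assay on NSCLC-N6 cells (Homo sapiens) for cytotoxicity, read by MTT assay (on this read-out higher numbers stand for weaker inhibition and lower numbers for stronger inhibition), and gives only a limit, > 72000 nM, so its position among the values shown is no more than that limit (the limit of > 72000 nM in this assay, at which 1 of the 3 values shown sits). Compound 3 `Cc1c(C=O)oc2cc(OCc3ccccc3)cc(OCc3ccccc3)c12` likewise gives a limit in this assay, > 80600 nM. The step that the two limits leave unreadable from compound 2 to compound 3 therefore cannot be read, because both ends sit at limits (the limit of > 80600 nM in this assay, at which 1 of the 3 values shown sits). Compound 1 `COc1cc(OC)c2c(C)c(C(N)=O)oc2c1C(N)=O`, which carries a carbamoyl on its aromatic ring as well as on the furan, gives a number in this assay, 22600 nM. Compound 4 `CCOC(=O)c1oc2c(C(N)=O)c(OCc3ccccc3)cc(OCc3ccccc3)c2c1C` differs from compound 2 by carbamoyl in place of hydrogen on an aromatic carbon. Among the compounds with values here, no measured step covers this change directly; the only bearing comes from compound 1, whose aromatic carbamoyl accompanies a value within the measurable range. Compound 4 is therefore expected to gain potency by about an at least 1.8-fold lower number from compound 2 to compound 4 (0.25 log units; that floor lies within the scatter) relative to the limit of compound 2, though this rests on one compound only. In this assay the value of compound 4 is estimated at 40000 nM, with a range from 15000 nM to 100000 nM.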

Compound 4, half-maximal inhibitory concentration: < 7200 nM
Compound 4 ended at the assay's limit; the forecaster's own chance of this, stated with the estimate: 45%; at least 5.5-fold (0.74 log units) between middle value and limit.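

With carbamoyl in place of hydrogen on an aromatic carbon, ortho to a benzyloxy group and para to a benzyloxy group, this assay gives an at least 10-fold lower number from compound 2 to compound 4 (1.00 log units; beyond the scatter). Compound 4 gives a limit and not a number, so this step is a floor and not a measured size: the limit of < 7200 nM in this assay, at which 1 of the 4 values shown sits. Unlike the change on the carbonyl carbon, whose step cannot be read, this change can be read, and it is the only pair shown that isolates carbamoyl on the aromatic ring.

Going by these compounds, whether the drop in the number belongs to carbamoyl itself, or would also follow from another group on this aromatic carbon, such as an amine or a carboxylic acid, stays open. On these data alone, how far compound 4 lies past its limit also stays open, as does the effect of the same change on compound 3.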